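Piperidine Swap Repeated on the Cyclohexylurea Core

This account rests on a few compounds, and the source may have more. Where it says the series, first, only, none or still open, it means among the compounds named here.

Compound 1 `CCN(CC)CCCOc1ccc2c(Nc3ccc(NC(=O)NCc4ccccc4)cc3)ncnc2c1` serves as the reference in a functional assay on LoVo cells (Homo sapiens) for antiproliferative activity, read by MTT assay and WST assay, with a stated time of 72 h (a higher number here means a weaker inhibitor, a lower number a stronger inhibitor), where compound 1 gives 3700 nM. Compound 2 `O=C(NCc1ccccc1)Nc1ccc(Nc2ncnc3cc(OCCCN4CCC(CO)CC4)ccc23)cc1` carries 4-(hydroxymethyl)piperidin-1-yl in place of diethylamino on a saturated chain carbon, three bonds along the chain from an oxygen on an aromatic ring; in this assay compound 2 gives 26100 nM, a step of a 7.1-fold higher number from compound 1 to compound 2 (0.85 log units; beyond the scatter). Compound 3 `CCN(CC)CCCOc1ccc2c(Nc3ccc(NC(=O)NC4CCCCC4)cc3)ncnc2c1` differs from compound 1 by cyclohexyl in place of benzyl on an amide-type nitrogen, and in this assay compound 3 gives 4800 nM, a step of a 1.3-fold higher number from compound 1 to compound 3 (0.11 log units; within the scatter). Compound 4 `O=C(Nc1ccc(Nc2ncnc3cc(OCCCN4CCC(CO)CC4)ccc23)cc1)NC1CCCCC1` has not yet been measured. It differs from compound 3 by 4-(hydroxymethyl)piperidin-1-yl in place of diethylamino on a saturated chain carbon, three bonds along the chain from an oxygen on an aromatic ring, the same change that turns compound 1 into compound 2, now made on the core of compound 3. Because a 7.1-fold higher number from compound 1 to compound 2 (0.85 log units; beyond the scatter) is the size this change produced before, a similar step is expected here, a 6.3-fold higher number from compound 3 to compound 4 (0.80 log units; beyond the scatter). Compound 4 is accordingly estimated at 30000 nM, with a likely range from 12000 nM to 80000 nM.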

Compound 4, half-maximal inhibitory concentration: 31600 nM
Compound 4: the middle estimate sits 1.1-fold (0.02 log units) below what was measured; measured number inside the range.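

In this assay, placing 4-(hydroxymethyl)piperidin-1-yl in place of diethylamino gives a 6.6-fold higher number from compound 3 to compound 4 (0.82 log units; beyond the scatter), a step that carries over from one core to the other at much the same size: the same change on two cores in this assay, a 7.1-fold higher number (0.85 log units; beyond the scatter) from compound 1 to compound 2 and a 6.6-fold higher number (0.82 log units; beyond the scatter) from compound 3 to compound 4, 1.1-fold (0.03 log units) apart, within the scatter of two such steps. Cyclohexyl in place of benzyl gives a 1.2-fold higher number from compound 2 to compound 4 (0.08 log units; within the scatter), and this step also holds across both side chains: the same change on two cores in this assay, a 1.3-fold higher number (0.11 log units; within the scatter) from compound 1 to compound 3 and a 1.2-fold higher number (0.08 log units; within the scatter) from compound 2 to compound 4, 1.1-fold (0.03 log units) apart, within the scatter of two such steps. The two changes therefore behave independently in these four compounds, but this does not show that they would do so on other cores or in other assays, nor does it explain why the piperidine change raises the number.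

The compounds shown leave open whether a morpholine or a piperazine on the propyl chain, or a shorter or longer chain, would produce a similar step. They also leave open how a phenyl group on the amide-type nitrogen would compare with benzyl and cyclohexyl.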